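Moving a Trifluoromethyl Group Around a Benzyl Ring

The source may report more compounds than this note shows. Statements on the series, on what has been measured and on what is new or still open speak of the compounds shown alone.

Compound 1 `COC(=O)C1=CN(C(C)C)C(=O)[C@@H]2C(CN3CCN(Cc4ccc([N+](=O)[O-])cc4)CC3)=CC[C@H]12` and compound 2 `COC(=O)C1=CN(C(C)C)C(=O)[C@@H]2C(CN3CCN(Cc4ccc(C(F)(F)F)cc4)CC3)=CC[C@H]12` share one core and differ only in the group carried on the benzyl ring. In a functional assay on Cortical neurone cells (Rattus norvegicus, strain Sprague-Dawley), read by MTT assay, with stated times of 24 h and 2 h, tested at 10 uM (on this read-out lower numbers stand for a weaker effect and higher numbers for a stronger effect at the one concentration tested), compound 1 gives 87.6%, and compound 2 gives 85.7%. The step of a number 1.9 percentage points lower from compound 1 to compound 2 (within the scatter) stays within the scatter. Of the two numbers, compound 2 holds the lower one, but the gap to compound 1 is within the scatter, so the two cannot be told apart. Compound 3 `COC(=O)C1=CN(C(C)C)C(=O)[C@@H]2C(CN3CCN(Cc4cccc(C(F)(F)F)c4)CC3)=CC[C@H]12` has the same atoms as compound 2, joined differently: 3-(trifluoromethyl)phenyl in place of 4-(trifluoromethyl)phenyl on a saturated chain carbon bound to an amine nitrogen in a ring. Going by the values given here, no measured step moves a group around the ring in this way; the only step at hand exchanged the group itself and stayed within the scatter. A step of a number 1.7 percentage points lower from compound 2 to compound 3 (within the scatter) is therefore expected, meaning no change beyond the scatter. Compound 3 is estimated at 84%, with a range from 70% to 95%.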

Compound 3, a percentage reported as activity, at one concentration (the size of the read-out at that concentration, not a potency): 85.5%
For compound 3 the middle estimate is 1.5 percentage points below the measured one, within the range that was stated.
By their numbers in this assay, from the lowest: compounds 3, 2 and 1 (each within the scatter of the next).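

Going by these compounds alone, until now only the group itself had been exchanged, and this is the first step that keeps the trifluoromethyl group and changes its place on the ring. In this assay, 3-(trifluoromethyl)phenyl in place of 4-(trifluoromethyl)phenyl gives a number 0.2 percentage points lower from compound 2 to compound 3 (within the scatter), so this shift of place can't be told from no change at all. Changing the group and its place together, with 3-(trifluoromethyl)phenyl in place of 4-nitrophenyl, gives a number 2.1 percentage points lower from compound 1 to compound 3 (within the scatter) and so also stays unresolved, while no measurement is at hand that would help explain these results.

The compounds shown leave open whether a carboxylic acid or an amine on the benzyl ring, or a longer chain in place of the benzyl link, would carry the number beyond the scatter. They also leave open how these compounds behave at other concentrations, as each is shown at only one.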